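The source may hold more compounds than are shown below. What is called first, only, known or untested is meant among the compounds shown, and "the series" means these compounds.

Going by the values given here, compound 2 `COc1cc(OC)cc(C(=O)Nc2cccc(-c3oc4cc(-c5ccc(F)cc5)ccc4c(=O)c3O)c2)c1` gives 4040 nM in a functional assay on MDA-MB-231 cells (Homo sapiens) for antiproliferative activity, read by CCK-8 assay, with a stated time of 72 h (on this read-out higher numbers stand for weaker inhibition and lower numbers for stronger inhibition), the lowest of the two numbers so far; its nearest neighbour, compound 1 `O=C(Nc1cccc(-c2oc3cc(-c4ccc(F)cc4)ccc3c(=O)c2O)c1)c1ccc(F)cc1F`, gives 11200 nM, and the step of a 2.8-fold lower number from compound 1 to compound 2 (0.44 log units; beyond the scatter) is the only step measured. Compound 3 `Cc1cc(C)cc(C(=O)Nc2cccc(-c3oc4cc(-c5ccc(F)cc5)ccc4c(=O)c3O)c2)c1` differs from compound 2 by 3,5-dimethylphenyl in place of 3,5-dimethoxyphenyl on a carbonyl carbon. Among the compounds with values here, no measured step bears directly on this exchange; the single step available concerns the same aryl group on the carbonyl carbon and was modest. A step of similar or smaller size in this assay is therefore expected, in either direction, and for compound 3 the estimate is 5000 nM, with a range of 2000 nM to 12500 nM, which means an expected step of a 1.2-fold higher number from compound 2 to compound 3 (0.09 log units; within the scatter).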

Compound 3, half-maximal inhibitory concentration: 11900 nM
Beside the measured number, compound 3's estimate is 2.4-fold (0.38 log units) below it, within the range that was stated.
By their numbers in this assay, from the lowest: compound 2; then compounds 1 and 3 (each within the scatter of the next).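

With 3,5-dimethylphenyl in place of 3,5-dimethoxyphenyl on the carbonyl carbon, the series gives a 2.9-fold higher number from compound 2 to compound 3 (0.47 log units; beyond the scatter), so a 3,5-substituted phenyl does not by itself carry the lower number. Compound 3 also stands level with the 2,4-difluorophenyl amide, a 1.1-fold higher number from compound 1 to compound 3 (0.03 log units; within the scatter), leaving compound 2 alone apart among these three compounds. No measurement shown here accounts for the difference.

Still open, on these data alone, is how 3,5-dihydroxyphenyl, 3,5-diethoxyphenyl or 3,4,5-trimethoxyphenyl would read on the same carbonyl carbon. A single methoxy group on the phenyl ring also remains to be placed against compound 2.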